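The source may hold more compounds than are shown below. What is called first, only, known or untested is meant among the compounds shown, and "the series" means these compounds.

Two measured compounds open the series. Compound 1 `COc1ccc(Cn2cc(CNC(=O)c3cn(-c4ccccc4)nc3-c3ccc(F)cc3)nn2)cc1OC` is one of them, and in a functional assay on MCF7 cells (Homo sapiens) for antiproliferative activity, read by sulforhodamine B assay, with a stated time of 48 h (on this read-out higher numbers stand for weaker inhibition of growth and lower numbers for stronger inhibition of growth), compound 1 reaches only the assay limit of > 100000 nM, so no number is known for it. Compound 2 `O=C(NCc1cn(Cc2ccc(Cl)cc2)nn1)c1cn(-c2ccccc2)nc1-c1ccc(Cl)cc1` is the other, and in this assay compound 2 gives 28800 nM. Within the data shown here, that makes compound 2 the only compound with an actual number: of the two values shown, one is a figure and the other is a limit, as the limit of > 100000 nM in this assay, at which 1 of the 2 values shown sits, records. Compound 3 `COc1ccc(Cn2cc(CNC(=O)c3cn(-c4ccccc4)nc3-c3ccc(Cl)cc3)nn2)cc1OC` has not been measured. It arises from compound 2 by the change (3,4-dimethoxyphenyl in place of 4-chlorophenyl on a saturated chain carbon bound to an aromatic nitrogen), that is, 3,4-dimethoxyphenyl in place of 4-chlorophenyl on a saturated chain carbon bound to an aromatic nitrogen. The 3,4-dimethoxybenzyl that enters is the same group carried by compound 1, and compound 1 shows only a limit. The step from compound 2 to compound 3 in this assay is therefore expected to run toward weaker inhibition, by a 2.3-fold higher number from compound 2 to compound 3 (0.35 log units; beyond the scatter), beyond the usual scatter. Compound 3 is estimated at 65000 nM, with a plausible range from 25000 nM to 100000 nM.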

Compound 3, concentration for 50% growth inhibition: > 100000 nM
Compound 3 ended at the assay's limit (the forecaster's own chance of this, stated with the estimate: 40%); at least 1.5-fold (0.18 log units) between middle value and limit.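

On the saturated chain carbon bound to an aromatic nitrogen, 3,4-dimethoxyphenyl in place of 4-chlorophenyl now has a direct reading in this assay, and the change gives an at least 3.4-fold higher number from compound 2 to compound 3 (0.54 log units; beyond the scatter). Among these compounds, until now the 3,4-dimethoxybenzyl had been seen only on compound 1, which differs from compound 2 in more than one place, so this is the first comparison in which that group is the only change, and it shows that growth inhibition at this position is weaker with it than with the 4-chlorobenzyl, although the true size of the step stays unknown. The step from fluoro to chloro on an aromatic carbon cannot be read, and the two dimethoxy compounds, compound 1 and compound 3, stay unranked against each other, as each stands at a limit and not at a number: the limit of > 100000 nM in this assay, at which 2 of the 3 values shown sit.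

Going by these compounds, it remains open whether a plain phenyl or a single methoxy group on the phenyl at this chain carbon would keep the growth inhibition of compound 2 or lose it. Also open, on these data alone, is how a fluoro in place of chloro on the aromatic carbon would read with the 4-chlorobenzyl in place.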